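A few compounds are considered here, and "the series" means these few. Any claim that something is new, unique, unknown or untested is made for them only; others in the source may bear on it.

Compound 1: `COc1cccc(N2C(=O)COc3ccc(-c4cnc(Cl)c(NS(=O)(=O)c5ccc(F)cc5)c4)cc32)c1` — > 40000 nM
Compound 2: `O=C1COc2ccc(-c3ccc(O)cc3)cc2N1` — > 40000 nM

In a functional assay on MCF7 cells (Homo sapiens) for antiproliferative activity, read by MTT assay, with a stated time of 72 h (on this read-out lower numbers stand for stronger inhibition and higher numbers for weaker inhibition), compound 2 gives only a limit of the assay, > 40000 nM, and no number. Compound 1 likewise reaches only a limit in this assay, > 40000 nM. Everything measured so far therefore rests on (the limit of > 40000 nM in this assay, at which 2 of the 2 values shown sit), and neither compound can be placed against the other.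

Compound 3, `COc1cccc(N2C(=O)COc3ccc(-c4ccc(O)cc4)cc32)c1`, is not yet measured. It differs from compound 2 by 3-methoxyphenyl in place of hydrogen on an amide-type nitrogen in a ring. Compound 1 already carries a 3-methoxyphenyl on its amide-type nitrogen in a ring, and it too sits at the limit in this assay, so the group itself has not yet lifted any compound of this series into a measurable range. Within the data shown here, with two limits and no measured step, the expectation for the step from compound 2 to compound 3 is none beyond the scatter, and most likely another limit. The estimate for compound 3 in this assay is 60000 nM, within 20000 nM to 150000 nM, which means an expected step that the limit leaves unreadable from compound 2 to compound 3.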

Compound 3, half-maximal inhibitory concentration: > 40000 nM
Compound 3: no number, only a limit (the forecaster's own chance of this, stated with the estimate: 75%); the middle value does not contradict the limit.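

In this assay compound 3 gives only a limit (> 40000 nM) and no number, so no step can be read between compound 2 and compound 3. All three compounds share the same result: the limit of > 40000 nM in this assay, at which 3 of the 3 values shown sit. The compounds shown leave open whether any change to the shared core gives a measurable value in this assay.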